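Trimethoxyphenyl on the core: extending the methoxy step

A few compounds are considered here, and "the series" means these few. Any claim that something is new, unique, unknown or untested is made for them only; others in the source may bear on it.

The series shares the enone-linked core with a pendant aryl group; compound 2 `COc1cc(/C=C/C(=O)c2cccc(-n3cc(-c4ccccc4)[nH]c3=O)c2)cc(OC)c1OC` carries phenyl, compound 3 `COc1ccc(-c2cn(-c3cccc(C(=O)/C=C/c4cc(OC)c(OC)c(OC)c4)c3)c(=O)[nH]2)cc1` carries 4-methoxyphenyl, and compound 1 `COc1cc(/C=C/C(=O)c2cccc(-n3cc(-c4ccc(Cl)cc4)[nH]c3=O)c2)cc(OC)c1OC` carries 4-chlorophenyl. In a functional assay on A549 cells (Homo sapiens) for inhibition (a lower number here means a stronger inhibitor of growth, a higher number a weaker inhibitor of growth), compound 2 gives 4030 nM and compound 3 gives 11800 nM. For compound 1 no number is reported in this assay, only "not active" (no number reported). Within the numbers at hand compound 3 stands highest, its nearest neighbour being compound 2, and the step of a 2.9-fold higher number from compound 2 to compound 3 (0.47 log units; beyond the scatter) lies beyond the scatter.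

Compound 4 `COc1cc(/C=C/C(=O)c2cccc(-n3cc(-c4cc(OC)c(OC)c(OC)c4)[nH]c3=O)c2)cc(OC)c1OC` is the next member: 3,4,5-trimethoxyphenyl in place of 4-methoxyphenyl on an aromatic carbon. Going by the values given here, the only measured step that bears on this change is the one from compound 2 to compound 3, where a single methoxy entering on the aryl ring raised the number by a 2.9-fold higher number from compound 2 to compound 3 (0.47 log units; beyond the scatter). Compound 4 adds two further methoxy groups to the same aryl ring. Among the compounds with values here, with no opposite example, the expectation is that the number in this assay rises again rather than falls, by a step of roughly the same order as before, with a real chance that no number is obtained at all. For compound 4 the estimated step is a 2.1-fold higher number from compound 3 to compound 4 (0.33 log units; beyond the scatter). Compound 4 is therefore expected to give 25000 nM in this assay, within a range of 8000 nM to 80000 nM.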

Compound 4, concentration for 50% growth inhibition: 3030 nM
Estimate against measurement, compound 4: 8.3-fold (0.92 log units) above; measured number outside the range, below it.
By their numbers in this assay, from the lowest: compounds 4 and 2 (each within the scatter of the next); then compound 3.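

In this assay the aryl position does not follow a simple trend with added methoxy groups: a 2.9-fold higher number from compound 2 to compound 3 (0.47 log units; beyond the scatter) is followed by a change in the opposite direction, a 3.9-fold lower number from compound 3 to compound 4 (0.59 log units; beyond the scatter) for 3,4,5-trimethoxyphenyl in place of 4-methoxyphenyl. Set against the plain phenyl of compound 2, the change gives a 1.3-fold lower number from compound 2 to compound 4 (0.12 log units; within the scatter) and so leaves these two compounds indistinguishable in this read-out, which shows that this position accepts the larger 3,4,5-trimethoxyphenyl group without a measurable loss relative to phenyl. Going by these compounds alone, the weaker result for compound 3 therefore cannot be read as a general penalty for methoxy on this ring, and within these three compounds it is the single 4-methoxyphenyl group that stands apart.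

Still open, going by these compounds, is how an amine, a carboxylic acid or a longer alkoxy chain on this aryl ring would compare with these numbers, and how the 4-chlorophenyl of compound 1, reported as "not active" (no number reported) and so without a number to compare, fits the picture. Nothing at hand explains why the direction reverses between these steps.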